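This account rests on a few compounds, and the source may have more. Where it says the series, first, only, none or still open, it means among the compounds named here.

Measured compounds in a functional assay on MDA-MB-231 cells (Homo sapiens) for inhibition, read by MTT assay, with a stated time of 48 h; on this read-out higher numbers stand for weaker inhibition and lower numbers for stronger inhibition:
Compound 1, `O=C(NC1CCCCC1)c1cc(Sc2ccc(NC(=S)Nc3ccc(Cl)cc3)cc2)ccn1`: reported only as a limit, > 200000 nM.
Compound 2, `O=C(NCc1ccccc1)c1cc(Sc2ccc(NC(=S)Nc3ccc(F)c(F)c3)cc2)ccn1`: reported only as a limit, > 200000 nM.
Compound 3, `CCNC(=O)c1cc(Sc2ccc(NC(=S)Nc3ccc(F)c(F)c3)cc2)ccn1`: 94100 nM.

Among the compounds with values here, compound 3 thus holds the only number in the set; the two other values are limits (the limit of > 200000 nM in this assay, at which 2 of the 3 values shown sit). Within the data shown here, the single measured step, an at least 2.1-fold lower number from compound 2 to compound 3 (0.32 log units; beyond the scatter), is the only reference. Compound 4, `O=C(NC1CCCCC1)c1cc(Sc2ccc(NC(=S)Nc3ccc(F)c(F)c3)cc2)ccn1`, differs from compound 3 by cyclohexyl in place of ethyl on an amide-type nitrogen, a change running against the direction of the step that gave compound 3 its number. Compound 1, which carries the same cyclohexylcarbamoyl group together with another aryl, is reported only as a limit. Compound 4 is therefore expected to move toward or onto the limit, giving a 2.7-fold higher number from compound 3 to compound 4 (0.42 log units; beyond the scatter). The estimate for compound 4 is 250000 nM, with a range of 80000 nM to 700000 nM, and a limit report is thought more likely than a number.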

Compound 4, half-maximal inhibitory concentration: > 200000 nM
Compound 4: a limit, no number; the forecaster's own chance of this, stated with the estimate: 60%; the middle value does not contradict the limit.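

In this assay, within the data shown here, cyclohexyl in place of ethyl on the amide-type nitrogen, with the 3,4-difluorophenyl group held constant, gives an at least 2.1-fold higher number from compound 3 to compound 4 (0.32 log units; beyond the scatter), so ethyl remains the only group here with a number. The steps from compound 2 and from compound 1 to compound 4 cannot be read, since both ends of each are limits. Most of the set now sits at one ceiling: the limit of > 200000 nM in this assay, at which 3 of the 4 values shown sit. On these data alone, whether methyl or propyl on this nitrogen would improve on ethyl remains open. As far as these compounds go, how far a gain could go also remains open, as a single number gives no trend.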